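The source may report more compounds than this note shows. Statements on the series, on what has been measured and on what is new or still open speak of the compounds shown alone.

Working notes on the series. The shared core carries a sulfonyl-linked phenyl ring, and the three measured compounds differ only in what sits on that ring. In an assay on HeLa cells for displacement of a labelled ligand from 5-hydroxytryptamine receptor 6 (Homo sapiens) (on this read-out lower numbers stand for stronger inhibition and higher numbers for weaker inhibition), compound 1 `CN1CCC(c2n[nH]c3ccc(S(=O)(=O)c4cccc(Cl)c4)cc23)CC1` gives 19 nM. Compound 2 `Cc1cccc(S(=O)(=O)c2ccc3[nH]nc(C4CCN(C)CC4)c3c2)c1` gives 50 nM in this assay. Compound 3 `CN1CCC(c2n[nH]c3ccc(S(=O)(=O)c4ccc(F)cc4)cc23)CC1` gives 66 nM in this assay, the highest of the three numbers, although the gap a 1.3-fold higher number from compound 2 to compound 3 (0.12 log units; within the scatter) lies within the scatter, so no order between those two can be read. The step of a 3.5-fold higher number from compound 1 to compound 3 (0.54 log units; beyond the scatter) lies beyond the scatter, as does a 2.6-fold higher number from compound 1 to compound 2 (0.42 log units; beyond the scatter).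

Compound 4 `CC(C)c1ccc(S(=O)(=O)c2ccc3[nH]nc(C4CCN(C)CC4)c3c2)cc1` is not yet measured. It differs from compound 3 by isopropyl in place of fluoro on an aromatic carbon. For the measured compounds named here, no measured step exchanges fluoro for isopropyl, nor any group for isopropyl; the only steps that touch this ring are a 3.5-fold higher number from compound 1 to compound 3 (0.54 log units; beyond the scatter) and a 1.3-fold higher number from compound 2 to compound 3 (0.12 log units; within the scatter), both modest, and neither compares groups that match the present change. Going by the values given here, with no direct precedent, nothing beyond the scatter is expected in this assay, and the estimated step of a 1.1-fold lower number from compound 3 to compound 4 (0.04 log units; within the scatter) is set close to no change, with a wide range to cover the uncertainty. Compound 4 is expected to give about 60 nM, between 20 nM and 180 nM.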

Compound 4, inhibition constant: 14 nM
For compound 4 the middle estimate is 4.3-fold (0.63 log units) above the measured one; the measured number lies below the stated range.
By their numbers in this assay, from the lowest: compounds 4 and 1 (each within the scatter of the next); then compounds 2 and 3 (each within the scatter of the next).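

At the aromatic carbon para to a large group, only fluoro had been seen so far; a 4.7-fold lower number from compound 3 to compound 4 (0.67 log units; beyond the scatter) shows in this assay that this carbon also accepts isopropyl, with a shift towards stronger inhibition that lies beyond the scatter. The 4-isopropylphenyl group also separates from the 3-methylphenyl group, as a 3.6-fold lower number from compound 2 to compound 4 (0.55 log units; beyond the scatter) lies beyond the scatter, while a 1.4-fold lower number from compound 1 to compound 4 (0.13 log units; within the scatter) lies within it, so no order can be read between those two compounds and the 3-chlorophenyl group no longer stands alone at the low end of the numbers. No evidence at hand accounts for this step, so the shift stands here as an observation only.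

With one exchange at this carbon, the series cannot show whether the lower number is particular to isopropyl or would also appear with a tert-butyl group, a methoxy group or an amine in the same place. As far as these compounds go, it also remains open whether isopropyl and chloro would add up on one ring, and whether the same exchange would give a step of similar size on the core of another compound.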